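An Aromatic Isoxazole in Place of a Saturated Ring

The source may report more compounds than this note shows. Statements on the series, on what has been measured and on what is new or still open speak of the compounds shown alone.

The compounds measured in an assay for inhibition of histone-lysine N-methyltransferase EZH2 variant Y641N (Homo sapiens), read by scintillation counting, with a stated time of 60 min, in the presence of a further agent that is not named here; a lower number here means a stronger inhibitor, a higher number a weaker inhibitor:
compound 1 `COC(c1cc(Cl)c2c(c1Cl)C(=O)N(Cc1c(C)cc(C)[nH]c1=O)CC2)C1CCOC1`: 130 nM; 30 nM; 1.9 nM; 0.6 nM (4 entries)
compound 2 `Cc1cc(C)c(CN2CCc3c(Cl)cc(C(CO)c4ccon4)c(Cl)c3C2=O)c(=O)[nH]1`: 360 nM; 24 nM (2 entries)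
compound 3 `Cc1cc(C)c(CN2CCc3c(Cl)cc([C@@H](CO)[C@@H]4CCCO4)c(Cl)c3C2=O)c(=O)[nH]1`: 135 nM

Compound 1 and compound 2 each carry several entries in this assay, and as the several entries of compound 1 in this assay, 130 nM; 30 nM; 1.9 nM; 0.6 nM (4 entries) and the several entries of compound 2 in this assay, 360 nM; 24 nM (2 entries) show, those entries spread widely. Compound 3 has a single number, and two further entries without one; on that single value it lies within the span reported for compound 1 and for compound 2. Among the compounds with values here, no two of the three measured compounds differ in only one place, so no measured step exists to lean on.

Compound 4 `Cc1cc(C)c(CN2CCc3c(Cl)cc(-c4c(C)noc4C)c(Cl)c3C2=O)c(=O)[nH]1` has not been measured. It differs from compound 3 in one place: a group of 7 heavy atoms (5 carbon, 1 nitrogen, 1 oxygen; one five-membered aromatic ring with 2 hetero atoms) in place of a group of 8 heavy atoms (6 carbon, 2 oxygen; one five-membered non-aromatic ring with 1 hetero atom), on an aromatic carbon. The 3,5-dimethyl-1,2-oxazol-4-yl group carries 0 hydrogen-bond donors where the departing group carries 1, and it sits on the aromatic carbon ortho to a chloro group and meta to a fused ring. Within the data shown here, with no measured step to guide the size, the direction rests on the change alone. Compound 4 is expected to show a 2.3-fold lower number from compound 3 to compound 4 (0.35 log units; beyond the scatter). Compound 4 is estimated at 60 nM, with a range from 8 nM to 450 nM.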

Compound 4, inhibition constant: 1.15 nM
Estimate against measurement, compound 4: 52-fold (1.72 log units) above, and the stated range ends above it.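

In this assay, within the data shown here, placing the 3,5-dimethyl-1,2-oxazol-4-yl group on this aromatic carbon, ortho to a chloro group, gives a 120-fold lower number from compound 3 to compound 4 (2.07 log units; beyond the scatter), the only measured step at this position, and a large one. The position therefore responds strongly to the group it carries, and compound 4 reaches its low number without a hydrogen-bond donor or defined stereocentres in that group. The exact size of the step needs caution, as compound 3 rests on a single number and entries for a related compound spread widely: the several entries of compound 1 in this assay, 130 nM; 30 nM; 1.9 nM; 0.6 nM (4 entries)

The change alters several features at once, so the compounds shown do not separate the contribution of the aromatic ring, its two methyl groups and the departing hydrogen-bond donor. On these data alone, it remains open whether an unsubstituted 1,2-oxazole, a phenyl ring or a pyrazole would match the 3,5-dimethyl-1,2-oxazol-4-yl group here.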